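Tetrazole side-chain amides on the shared core

This account rests on a few compounds, and the source may have more. Where it says the series, first, only, none or still open, it means among the compounds named here.

Compound 3 `CCCCNC(=O)CCCn1nnnc1[C@@H](COCc1ccccc1)NC(=O)C(C)(C)N` gives the lowest of the three numbers in an assay on isolated protein for displacement of a labelled ligand from growth hormone secretagogue receptor type 1 (Homo sapiens), with a stated time of 1 h (on this read-out higher numbers stand for weaker inhibition and lower numbers for stronger inhibition), at 1780 nM. Compound 1 `CC(C)(N)C(=O)N[C@H](COCc1ccccc1)c1nnnn1CC#N` gives 4170 nM and compound 2 `CC(C)(N)C(=O)N[C@H](COCc1ccccc1)c1nnnn1CCC#N` gives 2940 nM. The gap a 2.3-fold lower number from compound 1 to compound 3 (0.37 log units; beyond the scatter) lies beyond the scatter, while a 1.7-fold lower number from compound 2 to compound 3 (0.22 log units; within the scatter) and a 1.4-fold lower number from compound 1 to compound 2 (0.15 log units; within the scatter) do not, so compound 3 is separated only from compound 1.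

Compound 4 `CC(C)(N)C(=O)N[C@H](COCc1ccccc1)c1nnnn1CCC(=O)NCc1ccccc1` is not yet measured. It differs from compound 3 by benzylcarbamoyl in place of (butylcarbamoyl)methyl on a saturated chain carbon, two bonds along the chain from an aromatic nitrogen. For the measured compounds named here, no measured step exchanges one amide substituent for another; the steps that bear on the change are those that build the side chain out from the nitrile, a 1.7-fold lower number from compound 2 to compound 3 (0.22 log units; within the scatter) and a 2.3-fold lower number from compound 1 to compound 3 (0.37 log units; beyond the scatter), both small. Lengthening and adding the amide brought at most a modest gain, and exchanging butyl for benzyl on the same amide has no precedent here. A step of a 1.4-fold lower number from compound 3 to compound 4 (0.14 log units; within the scatter) is therefore expected, within or at the edge of the scatter. Compound 4 is estimated at 1300 nM, with a range from 500 nM to 3500 nM.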

Compound 4, inhibition constant: 1070 nM
Beside the measured number, compound 4's estimate is 1.2-fold (0.08 log units) above it; low and high end bracket the measured number.
By their numbers in this assay, from the lowest: compounds 4, 3, 2 and 1 (each within the scatter of the next, the first and the last beyond it).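

Benzylcarbamoyl in place of (butylcarbamoyl)methyl, on a saturated chain carbon two bonds along the chain from an aromatic nitrogen, leaves compounds 3 and 4 unseparated in this assay (a 1.7-fold lower number from compound 3 to compound 4 (0.22 log units; within the scatter)), so this position accepts a six-membered aromatic ring of carbon only on the amide as well as an open butyl chain. The benzyl amide also stands clear of both nitriles, modestly so, with a 2.7-fold lower number from compound 2 to compound 4 (0.44 log units; beyond the scatter) and a 3.9-fold lower number from compound 1 to compound 4 (0.59 log units; beyond the scatter); compound 3 was separated only from compound 1, whereas compound 4 is separated from compound 2 as well. Nothing in the data shown explains these steps.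

Still open, on these data alone, is whether a phenethyl group or a substituted benzyl group on the amide nitrogen would move the number beyond the scatter from compound 4. Equally open, as far as these compounds go, is how a carboxylic acid or a primary amine at the end of the side chain would compare with these amides.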